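Swapping a pyridine for a pyrimidine on the quinolinone core

The source may report more compounds than this note shows. Statements on the series, on what has been measured and on what is new or still open speak of the compounds shown alone.

Compound 3 `CCCn1ccc2cc(-c3cccnc3)cc(Cl)c2c1=O` is one of three measured analogues sharing the same core; the others are compound 1 `CCCn1ccc2cc(N3CCC(O)CC3)cc(Cl)c2c1=O` and compound 2 `CCCn1ccc2cc(-c3ccncc3)cc(Cl)c2c1=O`. In a functional assay on CHO cells for agonist activity at metabotropic glutamate receptor 2 (Homo sapiens), read by GTPgammaS binding (a lower number here means a smaller maximal response, a higher number a larger maximal response), compound 1 gives 106%, compound 2 gives 73%, and compound 3 gives 83%. Compound 3 therefore holds the second-highest value of the three, the move being a number 23 percentage points lower from compound 1 to compound 3 (beyond the scatter), while a number 10 percentage points higher from compound 2 to compound 3 (within the scatter).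

Compound 4 `CCCn1ccc2cc(-c3cncnc3)cc(Cl)c2c1=O` differs from compound 3 in one spot: pyrimidin-5-yl in place of pyridin-3-yl on an aromatic carbon. The step most alike is the one between the two pyridyl isomers, a number 10 percentage points higher from compound 2 to compound 3 (within the scatter), whereas both replacements of the 4-hydroxypiperidin-1-yl group by an aromatic ring lowered the response, seen in a number 33 percentage points lower from compound 1 to compound 2 (beyond the scatter) and a number 23 percentage points lower from compound 1 to compound 3 (beyond the scatter). Exchanging one six-membered aromatic ring for another has so far produced no step beyond the scatter, so compound 4 is expected to stay close to compound 3, with a step of a number 5 percentage points lower from compound 3 to compound 4 (within the scatter). The estimate for compound 4 is 78%, within 60% to 95%.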

Compound 4, largest response reached (Emax), in percent of the reference or control that the assay uses: 28%
The estimate for compound 4 lay 50 percentage points above the measured number; measured number below the stated range.
By their numbers in this assay, from the lowest: compound 4; then compounds 2 and 3 (each within the scatter of the next); then compound 1.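

The change of ring here is not a small one: in this assay, replacing pyridin-3-yl with pyrimidin-5-yl, which has a second ring nitrogen, gives a number 55 percentage points lower from compound 3 to compound 4 (beyond the scatter) even though the two pyridyl isomers lie within the scatter of each other. The pyrimidin-5-yl group also falls clearly short of the other two groups at this aromatic carbon, with a number 45 percentage points lower from compound 2 to compound 4 (beyond the scatter) and a number 78 percentage points lower from compound 1 to compound 4 (beyond the scatter), so aromatic rings of the same size are not interchangeable at this position. No measurement here accounts for this drop.

Still open, as far as these compounds go, is whether the second ring nitrogen or its placement in the ring matters more, which a pyrazin-2-yl or pyrimidin-2-yl group could help to separate. From the compounds shown here alone, how a plain phenyl ring or a morpholin-4-yl group would compare at this carbon also remains unknown.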